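The source may report more compounds than this note shows. Statements on the series, on what has been measured and on what is new or still open speak of the compounds shown alone.

Compound 2 `O=C([C@@H]1CCCN1C(=O)N1CCOCC1)N1CCC(NS(=O)(=O)c2cc(S(=O)(=O)c3ccccc3)ccc2C(F)(F)F)CC1` gives the lowest of the two numbers in an assay on isolated protein for binding affinity to secreted frizzled-related protein 1 (Homo sapiens), read by fluorescence (a higher number here means a weaker inhibitor, a lower number a stronger inhibitor), at 40 nM; compound 1 `O=C([C@@H]1CCCN1C(=O)c1ccncc1)N1CCC(NS(=O)(=O)c2cc(S(=O)(=O)c3ccccc3)ccc2C(F)(F)F)CC1` sits at 70 nM, and the step of a 1.8-fold lower number from compound 1 to compound 2 (0.24 log units; within the scatter) stays within the scatter. Compound 3 `CN1CCC[C@H]1C(=O)N1CCC(NS(=O)(=O)c2cc(S(=O)(=O)c3ccccc3)ccc2C(F)(F)F)CC1` carries methyl in place of (morpholin-4-yl)carbonyl on an amine nitrogen in a ring, so the acyl group on that ring nitrogen is removed altogether rather than exchanged. Going by the values given here, only the step from compound 1 to compound 2 bears on this, and it swaps one acyl group for another without a shift beyond the scatter; a loss of the whole group is a larger change with no precedent here. For compound 3 a modest weakening is expected, a 2.5-fold higher number from compound 2 to compound 3 (0.40 log units; beyond the scatter), giving an estimated 100 nM in this assay, likely between 30 nM and 400 nM.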

Compound 3, half-maximal inhibitory concentration: 120 nM
For compound 3 the middle estimate is 1.2-fold (0.08 log units) below the measured one; low and high end bracket the measured number.
By their numbers in this assay, from the lowest: compounds 2, 1 and 3 (each within the scatter of the next, the first and the last beyond it).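

On the amine nitrogen in a ring, the acyl group can go entirely and a measurable number remains: in this assay, methyl in place of (morpholin-4-yl)carbonyl gives a 3.0-fold higher number from compound 2 to compound 3 (0.48 log units; beyond the scatter) and this modest step lies beyond the scatter. Methyl in place of (pyridin-4-yl)carbonyl gives a 1.7-fold higher number from compound 1 to compound 3 (0.23 log units; within the scatter) and this step stays within the scatter, so at this position methyl cannot be told apart from that acyl group. No evidence on the cause of either step is at hand.

Still open, from the compounds shown here alone, is how a longer chain such as ethyl, or an acetyl group, would read at this nitrogen.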